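The source may hold more compounds than are shown below. What is called first, only, known or untested is meant among the compounds shown, and "the series" means these compounds.

Measured in a functional assay for inhibition, with Rattus norvegicus as the target; a lower number here means a stronger inhibitor, a higher number a weaker inhibitor:
- compound 1 `CC(/N=c1\c(O)c(O)\c1=N/c1ccc(Br)cc1)C(C)(C)C`: 1260 nM
- compound 2 `CC(/N=c1\c(O)c(O)\c1=N/c1ccc(OC(F)(F)F)cc1)C(C)(C)C`: > 30000 nM (a limit of the assay, not a number)
- compound 3 `CC(=O)c1ccc(/N=c2\c(O)c(O)\c2=N/C(C)C(C)(C)C)cc1`: 21200 nM

Of the two numeric values, the higher belongs to compound 3. Acetyl in place of bromo gave a 17-fold higher number from compound 1 to compound 3 (1.23 log units; beyond the scatter).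

Compound 4 `CC(/N=c1\c(O)c(O)\c1=N/c1ccc(-n2ccnc2)cc1)C(C)(C)C` differs by 1H-imidazol-1-yl in place of acetyl on an aromatic carbon, with 1H-imidazol-1-yl in place of acetyl on an aromatic carbon. Within the data shown here, three measured steps concern this same place. Both replacements of bromo were large: an at least 23-fold higher number from compound 1 to compound 2 (1.37 log units; beyond the scatter) and a 17-fold higher number from compound 1 to compound 3 (1.23 log units; beyond the scatter). Between the two non-bromo groups, the series shows an at least 1.4-fold lower number from compound 2 to compound 3 (0.15 log units; that floor lies within the scatter), whose floor lies within the scatter. As far as these compounds go, the imidazolyl group itself is untested, so no step beyond the scatter is expected: the estimated change is a 1.4-fold lower number from compound 3 to compound 4 (0.15 log units; within the scatter). For compound 4 the expected value is 15000 nM, within an estimated range of 3000 nM to 30000 nM.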

Compound 4, half-maximal inhibitory concentration: > 30000 nM
Compound 4 was reported as a limit; the forecaster's own chance of this, stated with the estimate: 30%; middle value at least 2.0-fold (0.30 log units) from the limit.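

In this assay compound 4 sits at a limit of the assay, > 30000 nM, and not at a number. At this position on the aromatic ring, 1H-imidazol-1-yl joins the groups that fall well short of bromo, an at least 23-fold higher number from compound 1 to compound 4 (1.37 log units; beyond the scatter), while the comparison with acetyl gives only a floor, an at least 1.4-fold higher number from compound 3 to compound 4 (0.15 log units; that floor lies within the scatter). The step between compound 2 and compound 4 cannot be read: the limit of > 30000 nM in this assay, at which 2 of the 4 values shown sit.

As far as these compounds go, whether chloro or iodo at this position would keep the value of compound 1 stays open. So does whether an amine or a carboxylic acid here would give a measurable number.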